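Tetrabromobenzotriazoles: swapping a hydroxypropyl side chain for a dihydroxyethyl one

The source may report more compounds than this note shows. Statements on the series, on what has been measured and on what is new or still open speak of the compounds shown alone.

Measured compounds:
- compound 1, `C[C@H](O)CCn1nc2c(Br)c(Br)c(Br)c(Br)c2n1`: 10%
- compound 2, `CC(O)CCn1nc2c(Br)c(Br)c(Br)c(Br)c2n1`: 0%

In a functional assay on CCRF-CEM cells (Homo sapiens) for antiproliferative activity, read by MTT assay, with a stated time of 48 h, tested at 100 uM (on this read-out lower numbers stand for a stronger effect and higher numbers for a weaker effect at the one concentration tested), compound 2 gives 0%, and compound 1 gives 10%; the two values sit within the scatter of each other, so neither can be called the more effective. Within the data shown here, the one measured step, a number 10 percentage points lower from compound 1 to compound 2 (within the scatter), involves no change of atoms or bonds at all; the two compounds differ only in that (the fact that one of compounds 1 and 2 is drawn with a defined configuration and the other without, at the place where they differ), which is why no effect on the read-out is to be expected from it.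

Compound 3, `OCC(O)Cn1nc2c(Br)c(Br)c(Br)c(Br)c2n1`, has not yet been measured. It differs from compound 2 in a single place: 1,2-dihydroxyethyl in place of 2-hydroxypropyl on a saturated chain carbon bound to an aromatic nitrogen. Among the measured compounds shown here, no measured step bears directly on this change, since the only step available concerns the drawing of a stereocentre rather than a change of group, so there is no measured basis for predicting a shift beyond the scatter. The estimated step of a number 12 percentage points higher from compound 2 to compound 3 (beyond the scatter) is therefore expected to be small. Compound 3 is thus expected to give about 12%, with a likely range from 0% to 40%.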

Compound 3, a percentage reported as activity, at one concentration (the size of the read-out at that concentration, not a potency): 1%
Compound 3: middle estimate off by 11 percentage points, on the high side; low and high end bracket the measured number.
By their numbers in this assay, from the lowest: compounds 2, 3 and 1 (each within the scatter of the next).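

In this assay, among these compounds, swapping the 2-hydroxypropyl side chain for 1,2-dihydroxyethyl gives a number 1 percentage points higher from compound 2 to compound 3 (within the scatter), and the same exchange gives a number 9 percentage points lower from compound 1 to compound 3 (within the scatter), so this is the first change of group at this position, and in neither comparison can the two compounds be told apart. The entering group has 2 hydrogen-bond donors and 2 acceptors where the leaving group has 1 of each, so at the one concentration tested this position tolerates that exchange without a readable difference in the number. Nothing in the available observations gives a reason for this outcome.

The compounds shown leave open whether an amine, a carboxylic acid or a longer chain at the same place would also stay within the scatter of these numbers, since every side chain here carries hydroxyl groups and is of similar size. They also leave open whether compound 2 and compound 3 would still match at lower concentrations, as a read-out at a single concentration is not a potency.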